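Swapping the Aryl Group: From Compound 2 to Compound 3

The source may hold more compounds than are shown below. What is called first, only, known or untested is meant among the compounds shown, and "the series" means these compounds.

Compound 1, `CC1CC1c1cc(NC(=O)Cn2nnc(-c3ccccc3)n2)n(C2CCCCC2)n1`: 843 nM
Compound 2, `Cc1cc(NC(=O)Cn2nnc(-c3cccc(Cl)c3)n2)n(C2CCCCC2)n1`: 300 nM

Among the compounds with values here, in an assay on HEK293 cells for activation of Kir3.1/Kir3.2 (Homo sapiens), read by thallium flux (on this read-out higher numbers stand for an effect only at larger amounts of compound and lower numbers for an effect already at smaller amounts), compound 2 gives 300 nM, the lowest of the two numbers measured so far. Compound 1 gives 843 nM, a higher number, and the gap between the two lies beyond the usual scatter. Compound 1 and compound 2 differ in two places at once, so no single change can be read from that pair; the numbers only show that compound 2 acts at the smaller amount.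

Compound 3, `Cc1ccc(-c2nnn(CC(=O)Nc3cc(C)nn3C3CCCCC3)n2)cc1`, keeps the whole core of compound 2 and changes one group: 4-methylphenyl in place of 3-chlorophenyl on an aromatic carbon. Within the data shown here, no measured pair in this set isolates that position, so there is no direct precedent for the size or direction of the step. The two groups are of equal size and carry neither donors nor acceptors, so a modest change is expected, more likely toward a higher number than a lower one. The expected step of a 1.7-fold higher number from compound 2 to compound 3 (0.22 log units; within the scatter) is small, near the edge of the scatter. Compound 3 is therefore estimated at 500 nM, with a range from 150 nM to 1700 nM.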

Compound 3, half-maximal effective concentration: 111 nM
Estimate against measurement, compound 3: 4.5-fold (0.65 log units) above, outside the stated range (below it).
By their numbers in this assay, from the lowest: compound 3; then compound 2; then compound 1.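

Placing 4-methylphenyl in place of 3-chlorophenyl on an aromatic carbon of a five-membered aromatic ring with 4 nitrogen gives a 2.7-fold lower number from compound 2 to compound 3 (0.43 log units; beyond the scatter) in this assay. Within the data shown here, this is the first comparison in the set that differs in one place only, and it shows that this place on the shared core can move the number beyond the usual scatter. The two groups have the same count of heavy atoms, the same kind of ring, and no hydrogen-bond donors or acceptors, so those counts do not tell them apart, and nothing measured here says what lies behind the step.

The swap replaces the chlorine with a methyl group and also changes where the substituent sits on the phenyl ring, and the compounds shown do not tell these two changes apart; 4-chlorophenyl and 3-methylphenyl would separate them. Also open, on these data alone, is how this place responds to a substituent of another kind on the phenyl ring, such as an amine or a carboxylic acid.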